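Fluoro scan on the benzyl amide: compound 3

This account rests on a few compounds, and the source may have more. Where it says the series, first, only, none or still open, it means among the compounds named here.

Compound 2 `CC1=C(/C=C/C(C)=C/C=C/C(C)=C\C(=O)NCc2ccccc2)C(C)(C)CCC1n1ccnc1` holds the higher of two numbers in a functional assay on MCF7 cells (Homo sapiens) for inhibition, read by MTT assay (on this read-out lower numbers stand for stronger inhibition of growth and higher numbers for weaker inhibition of growth), at 9770 nM, while compound 1 `CC1=C(/C=C/C(C)=C/C=C/C(C)=C\C(=O)NCc2cccc(F)c2)C(C)(C)CCC1n1ccnc1` gives 1810 nM. Compound 3 `CC1=C(/C=C/C(C)=C/C=C/C(C)=C\C(=O)NCc2ccc(F)cc2)C(C)(C)CCC1n1ccnc1` differs from compound 2 by fluoro in place of hydrogen on an aromatic carbon, para to a large group. Within the data shown here, one measured step bears on this, at another aromatic carbon: a 5.4-fold higher number from compound 1 to compound 2 (0.73 log units; beyond the scatter), which is modest. A lower number than for compound 2 is therefore expected in this assay, though the size is uncertain with a single precedent. The estimated step is a 2.8-fold lower number from compound 2 to compound 3 (0.45 log units; beyond the scatter). For compound 3 the expected value is 3500 nM, with an estimated range of 1500 nM to 9000 nM.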

Compound 3, concentration for 50% growth inhibition: 1930 nM
Beside the measured number, compound 3's estimate is 1.8-fold (0.26 log units) above it; measured number inside the range.
By their numbers in this assay, from the lowest: compounds 1 and 3 (each within the scatter of the next); then compound 2.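

Fluoro para to a large group lowers the number as well: in this assay there is a 5.1-fold lower number from compound 2 to compound 3 (0.70 log units; beyond the scatter), so the gain on the benzyl amide is not confined to a single aromatic carbon. The 3-fluorophenyl and 4-fluorophenyl compounds cannot be told apart, with a 1.1-fold higher number from compound 1 to compound 3 (0.03 log units; within the scatter). Nothing available accounts for the gain. Going by these compounds, whether it is specific to fluoro remains open, since a chloro, methoxy or trifluoromethyl group at this carbon would test that. Whether a second fluoro on the same ring adds to the gain is also unsettled.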